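Acetyl in Place of Methyl on a Shared Core

A few compounds are considered here, and "the series" means these few. Any claim that something is new, unique, unknown or untested is made for them only; others in the source may bear on it.

In a functional assay on SK-BR-3 cells (Homo sapiens) for cytotoxicity, read by MTT assay, with a stated time of 72 h (on this read-out higher numbers stand for an effect only at larger amounts of compound and lower numbers for an effect already at smaller amounts), the three measured compounds stand as follows.
Compound 1 `CCc1cccc2c(OC)c(-c3occ(C)c3COC)ccc12` gives > 10 ug/mL, a limit of the assay.
Compound 2 `CCc1cccc2c(OC)c(-c3occ(C)c3COC(C)=O)ccc12` gives > 10 ug/mL, a limit of the assay.
Compound 3 `CCOc1c(-c2occ(C)c2COC)ccc2c(CC)cccc12` gives > 10 ug/mL, a limit of the assay.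

The change acetyl in place of methyl on an oxygen on a saturated carbon gives a step that the two limits leave unreadable from compound 1 to compound 2; the two cores differ by methyl in place of hydrogen on a saturated chain carbon bound to an oxygen on an aromatic ring, with a step that the two limits leave unreadable from compound 1 to compound 3. All that is known is the limit of > 10 ug/mL in this assay, at which 3 of the 3 values shown sit. Compound 4 `CCOc1c(-c2occ(C)c2COC(C)=O)ccc2c(CC)cccc12` carries the same change as compound 2, namely (acetyl in place of methyl on an oxygen on a saturated carbon), set on the core of compound 3, the place being identical in words. Because a step that the two limits leave unreadable from compound 1 to compound 2 is not readable and because the limit of > 10 ug/mL in this assay, at which 3 of the 3 values shown sit, holds for every value, the step is expected to be a step that the limit leaves unreadable from compound 3 to compound 4. Compound 4 is therefore estimated at 15 ug/mL, between 5 ug/mL and 50 ug/mL, most likely reported as a limit again.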

Compound 4, concentration for half-maximal effect: > 10 ug/mL
Compound 4: a limit, no number; the forecaster's own chance of this, stated with the estimate: 80%; the middle value lies beyond the limit too.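

In this assay compound 4 gives > 10 ug/mL as a limit, so neither of its steps, from compound 2 or from compound 3, can be read: the limit of > 10 ug/mL in this assay, at which 4 of the 4 values shown sit.
The compounds shown leave open what size either change has, and at what amount any of them acts.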